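Adding a Second Methyl to the Aryl Ring

The source may report more compounds than this note shows. Statements on the series, on what has been measured and on what is new or still open speak of the compounds shown alone.

Compound 1, `CCC1=C(O)c2c(oc(-c3ccccc3C)cc2=O)C(CC)(CC)C1=O`: 2.41 uM
Compound 2, `CCC1=C(O)c2c(oc(-c3ccc(OC)c(OC)c3OC)cc2=O)C(CC)(CC)C1=O`: 1.57 uM

In a functional assay on KBVIN cells (Homo sapiens) for antiproliferative activity, read by sulforhodamine B assay, with a stated time of 3 days (a higher number here means that more compound is needed for the effect, a lower number that less compound is needed), compound 1 gives 2.41 uM. Compound 2 gives 1.57 uM in this assay, and the gap between compound 1 and compound 2 falls within the usual scatter, so on these two numbers compound 1 stands beside compound 2 rather than apart from it. Compound 3, `CCC1=C(O)c2c(oc(-c3cc(C)ccc3C)cc2=O)C(CC)(CC)C1=O`, is not yet measured; it differs from compound 1 by methyl in place of hydrogen on an aromatic carbon. Among the measured compounds no pair differs in just this way, so nothing on hand shows what this particular addition does in this assay. With only that to go on, the expected step of a 1.1-fold lower number from compound 1 to compound 3 (0.04 log units; within the scatter) is small, no larger than the scatter itself, in either direction. Compound 3 is therefore estimated at 2.2 uM in this assay, with a range from 0.9 uM to 5.5 uM.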

Compound 3, concentration for half-maximal effect: 3.41 uM
Compound 3: the middle estimate sits 1.6-fold (0.19 log units) below what was measured; measured number inside the range.
By their numbers in this assay, from the lowest: compounds 2, 1 and 3 (each within the scatter of the next, the first and the last beyond it).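

Going by these compounds alone, the pair of compound 1 and compound 3 is the first here to differ in one place only, so it gives the first direct reading of a methyl on this aromatic carbon, meta to a large group and para to a methyl group. In this assay going from 2-methylphenyl to 2,5-dimethylphenyl gives a 1.4-fold higher number from compound 1 to compound 3 (0.15 log units; within the scatter) and so does not separate the two compounds: at this position, a methyl in place of hydrogen has no effect that can be told from the scatter. No measurement on hand offers an explanation for this result.

Going by these compounds, whether an ethyl group, an amine or a carboxylic acid at this position would shift the number beyond the scatter remains open. Also open, on these data alone, is whether a methyl on another carbon of this ring would behave the same way.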